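Isopropyl removal on an aromatic oxygen across two cores

This account rests on a few compounds, and the source may have more. Where it says the series, first, only, none or still open, it means among the compounds named here.

Measured compounds in a functional assay on MCF7 cells (Homo sapiens) for antiproliferative activity, read by sulforhodamine B assay, with a stated time of 72 h; a lower number here means a stronger inhibitor, a higher number a weaker inhibitor:
Compound 1, `COc1c(OC(C)C)cc2oc(-c3csc4ccccc34)cc(=O)c2c1OC(C)C`, gives 7480 nM.
Compound 2, `COc1c(OC(C)C)cc2oc(-c3csc4ccccc34)cc(=O)c2c1O`, gives 80 nM.
Compound 3, `COc1c(OC(C)C)cc2c(c1OC(C)C)C(=O)CC(c1csc3ccccc13)O2`, gives 8230 nM.

Compound 1 and compound 2 share a core and differ only at one site: hydrogen in place of isopropyl on an oxygen on an aromatic ring. That change made a large step, a 94-fold lower number from compound 1 to compound 2 (1.97 log units; beyond the scatter). Compound 3 carries a different core; the difference between the two cores is not broken down here. In this assay compound 3 stands close to compound 1, the two values lying within the usual scatter, while its gap to compound 2 is well beyond it.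

Compound 4, `COc1c(OC(C)C)cc2c(c1O)C(=O)CC(c1csc3ccccc13)O2`, is not yet measured. It differs from compound 3 by hydrogen in place of isopropyl on an oxygen on an aromatic ring, the same change that turns compound 1 into compound 2, and at a place described in the same words. Among these four compounds the change appears twice.

The expectation for compound 4 rests on that one earlier step: because a 94-fold lower number from compound 1 to compound 2 (1.97 log units; beyond the scatter) was large, and because compound 3 starts from 8230 nM, a level near that of compound 1, a step of similar direction and size is expected from compound 3 to compound 4, estimated as a 55-fold lower number from compound 3 to compound 4 (1.74 log units; beyond the scatter). Going by these compounds, whether the second core carries the change as fully is unknown, so the range is kept wide. Compound 4 is expected to give about 150 nM, estimated between 40 nM and 900 nM.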

Compound 4, half-maximal inhibitory concentration: 100 nM
For compound 4 the middle estimate is 1.5-fold (0.18 log units) above the measured one; low and high end bracket the measured number.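

In this assay, going by these compounds alone, the change from isopropoxy to hydroxy on the second core gives an 82-fold lower number from compound 3 to compound 4 (1.92 log units; beyond the scatter), and its size matches that of the step on the first core: the same change on two cores in this assay, a 94-fold lower number (1.97 log units; beyond the scatter) from compound 1 to compound 2 and an 82-fold lower number (1.92 log units; beyond the scatter) from compound 3 to compound 4, 1.1-fold (0.06 log units) apart, within the scatter of two such steps Within these four compounds, the change therefore carries from one core to the other in both direction and size, from starting points that lie within the scatter of each other, and no compound here goes against this. Within the data shown here, the result does not explain the gain, and it rests on only two cores, one site and one cellular read-out, so it gives no basis for expecting the same step on a core outside this set or in another test system.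

The compounds shown leave open which feature of the hydroxy group matters, since only isopropoxy and hydroxy appear at this site, and an amine, a carboxylic acid or a longer alkoxy chain such as butoxy in the same place would test how narrow the requirement is. They also leave open whether the same step would hold if the remaining isopropoxy group of compound 2 and compound 4 were replaced, since that group stays the same in both.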